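The compounds below may be only part of what the source reports. "The series", "measured", "known", "first", "only" and "open" are said of these compounds alone.

In an ADME assay on L6 cells (Rattus norvegicus) for cytotoxicity, read by resazurin assay, with a stated time of 70 h (on this read-out higher numbers stand for weaker inhibition and lower numbers for stronger inhibition), compound 1 `COc1cc(OC)cc(C(=O)Oc2ccc3c(c2)C(C)=CC(C)(C)N3Cc2ccccc2)c1` gives 24000 nM and compound 2 `CC1=CC(C)(C)N(Cc2ccccc2)c2ccc(OC(=O)C(C)(C)C)cc21` gives 170000 nM. Compound 3 `CCCCCCCC(=O)Oc1ccc2c(c1)C(C)=CC(C)(C)N2Cc1ccccc1` gives 220000 nM, within the scatter of compound 2. Compound 4 `CC1=CC(C)(C)N(Cc2ccccc2)c2ccc(OC(=O)C3CCCCC3)cc21` differs from it by cyclohexyl in place of heptyl on a carbonyl carbon. For the measured compounds named here, the closest precedent is a 1.3-fold higher number from compound 2 to compound 3 (0.11 log units; within the scatter), heptyl in place of tert-butyl, which stays within the scatter. The modest 7.1-fold higher number from compound 1 to compound 2 (0.85 log units; beyond the scatter) and a 9.2-fold higher number from compound 1 to compound 3 (0.96 log units; beyond the scatter) both remove 3,5-dimethoxyphenyl, a group absent from the pair at hand. No step beyond the scatter is therefore expected in this assay. The expected step is a 1.2-fold lower number from compound 3 to compound 4 (0.09 log units; within the scatter). Compound 4 is estimated at 180000 nM, with an expected range of 80000 nM to 400000 nM.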

Compound 4, half-maximal inhibitory concentration: > 230000 nM
Compound 4 ended at the assay's limit; the forecaster's own chance of this, stated with the estimate: 15%; middle value at least 1.2-fold (0.10 log units) from the limit.
By their numbers in this assay, from the lowest: compound 1; then compounds 2 and 3 (each within the scatter of the next). At a limit, above all of these: compound 4.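

In this assay compound 4 stands at a limit of the assay: the limit of > 230000 nM in this assay, at which 1 of the 4 values shown sits.

Cyclohexyl on this carbonyl carbon gives an at least 1.0-fold higher number from compound 3 to compound 4 (0.01 log units; that floor lies within the scatter) and an at least 1.3-fold higher number from compound 2 to compound 4 (0.13 log units; that floor lies within the scatter), so it cannot be separated from heptyl or tert-butyl. The gap to 3,5-dimethoxyphenyl is an at least 9.5-fold higher number from compound 1 to compound 4 (0.98 log units; beyond the scatter), which shows that a six-membered non-aromatic ring does not bring the lower number of compound 1.

Still open, as far as these compounds go, is whether that lower number goes with the aromatic ring or with its methoxy groups, which an unsubstituted phenyl on the same carbonyl carbon would address. From the compounds shown here alone, the true value of compound 4 also remains open.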